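Moving a Methyl Group Around the Piperidine Ring

The source may hold more compounds than are shown below. What is called first, only, known or untested is meant among the compounds shown, and "the series" means these compounds.

For the measured compounds named here, compound 2 `Cc1cc(C)c(-n2c(Cl)cn3c(CN4CCCC(C)C4)c(C(F)(F)F)nc23)c(C)c1` gives 5800 nM in an assay on cells for displacement of a labelled ligand from corticotropin-releasing factor receptor 1 (Homo sapiens), with a stated time of 100 min (a lower number here means a stronger inhibitor, a higher number a weaker inhibitor), the highest of the two numbers measured so far; its nearest neighbour, compound 1 `Cc1cc(C)c(-n2c(Cl)cn3c(CN(C)Cc4ccccc4)c(C(F)(F)F)nc23)c(C)c1`, gives 160 nM. Going by the values given here, the only measured step, a 36-fold higher number from compound 1 to compound 2 (1.56 log units; beyond the scatter), exchanged a benzyl(methyl)amino group for 3-methylpiperidin-1-yl on the saturated chain carbon bound to an aromatic carbon. Compound 3 `Cc1cc(C)c(-n2c(Cl)cn3c(CN4CCC(C)CC4)c(C(F)(F)F)nc23)c(C)c1`, not yet measured, differs from compound 2 only by 4-methylpiperidin-1-yl in place of 3-methylpiperidin-1-yl on a saturated chain carbon bound to an aromatic carbon. Among the compounds with values here, no measured step moves a methyl group within the same ring, so the step from compound 1 to compound 2 offers only weak guidance, and a shift of this kind is expected to stay within the usual scatter. The expected step in this assay is therefore a 1.2-fold lower number from compound 2 to compound 3 (0.06 log units; within the scatter). Compound 3 is expected to give about 5000 nM, within a range from 1500 nM to 15000 nM.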

Compound 3, inhibition constant: 3200 nM
The estimate for compound 3 lay 1.6-fold (0.19 log units) above the measured number, within the range that was stated.
By their numbers in this assay, from the lowest: compound 1; then compounds 3 and 2 (each within the scatter of the next).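

In this assay, moving the methyl group around the piperidine ring gives a step that cannot be told from the usual scatter (a 1.8-fold lower number from compound 2 to compound 3 (0.26 log units; within the scatter)), so the 3-methylpiperidin-1-yl and 4-methylpiperidin-1-yl groups are not distinguished at this place on the saturated chain carbon. The large gap to benzyl(methyl)amino holds for the second ring as well (a 20-fold higher number from compound 1 to compound 3 (1.30 log units; beyond the scatter)), so the loss seen with compound 2 is not confined to a single methyl placement among these two rings. Nothing available here explains the gap between benzyl(methyl)amino and the two methylpiperidines.

Plain piperidin-1-yl, with no methyl group, would help separate the contribution of the ring from that of the methyl. From the compounds shown here alone, how morpholin-4-yl or piperazin-1-yl, each carrying a second hetero atom in the ring, would compare at this place remains open.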